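The source may report more compounds than this note shows. Statements on the series, on what has been measured and on what is new or still open speak of the compounds shown alone.

In an assay on CHO cells for positive allosteric modulation of metabotropic glutamate receptor 5 (Homo sapiens), read by FLIPR (on this read-out higher numbers stand for an effect only at larger amounts of compound and lower numbers for an effect already at smaller amounts), three compounds of one shared core have been measured. Compound 1 `COc1cccc(C(=O)Nc2ccc(Cl)cc2CN2C(=O)c3ccccc3C2=O)c1` gives 1500 nM, and compound 2 `O=C(Nc1ccc(Cl)cc1CN1C(=O)c2ccccc2C1=O)C1CCCCC1` gives 1500 nM; the step of no change at the digits printed from compound 1 to compound 2 (within the scatter) lies within the scatter, so these two cannot be ordered. Compound 3 `O=C(Nc1ccc(Cl)cc1CN1C(=O)c2ccccc2C1=O)c1ncccc1O` gives 260 nM, the lowest of the three numbers; both a 5.8-fold lower number from compound 1 to compound 3 (0.76 log units; beyond the scatter) and a 5.8-fold lower number from compound 2 to compound 3 (0.76 log units; beyond the scatter) are beyond the scatter, so compound 3 stands apart from the other two by the same margin.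

Compound 4 `O=C(Nc1ccc(Cl)cc1CN1C(=O)c2ccccc2C1=O)c1cccnn1` carries the change (pyridazin-3-yl in place of 3-hydroxypyridin-2-yl on a carbonyl carbon). The two steps that bear on it are the ones that brought 3-hydroxypyridin-2-yl onto the carbonyl carbon, a 5.8-fold lower number from compound 1 to compound 3 (0.76 log units; beyond the scatter) and a 5.8-fold lower number from compound 2 to compound 3 (0.76 log units; beyond the scatter), each lowering the number in the same modest measure whether the departing group was aryl or cycloalkyl. Among the compounds with values here, compound 4 takes that group away again, and nothing among the measured compounds shows a pyridazin-3-yl on this carbonyl carbon. The expectation is therefore a return toward the numbers of compound 1 and compound 2, a step of roughly a 3.8-fold higher number from compound 3 to compound 4 (0.59 log units; beyond the scatter) upward in this assay, with wide uncertainty because only a 5.8-fold lower number from compound 1 to compound 3 (0.76 log units; beyond the scatter) and a 5.8-fold lower number from compound 2 to compound 3 (0.76 log units; beyond the scatter) inform it. Compound 4 is thus estimated at 1000 nM, within a range of 300 nM to 3500 nM.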

Compound 4, half-maximal effective concentration: > 100000 nM
Compound 4: a limit, no number; the forecaster's own chance of this, stated with the estimate: 10%; middle value at least 100-fold (2.00 log units) away from the limit.
By their numbers in this assay, from the lowest: compound 3; then compounds 1 and 2 (each within the scatter of the next). At a limit, above all of these: compound 4.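

In this assay, compound 4 yields only a limit and no number: the limit of > 100000 nM in this assay, at which 1 of the 4 values shown sits.

The earlier compounds had shown little difference between 3-methoxyphenyl and cyclohexyl on this carbonyl carbon, but the steps with pyridazin-3-yl, an at least 66-fold higher number from compound 1 to compound 4 (1.82 log units; beyond the scatter) and an at least 66-fold higher number from compound 2 to compound 4 (1.82 log units; beyond the scatter), show that the position does not accept every group, and that an aromatic ring here is not enough by itself. The step of an at least 380-fold higher number from compound 3 to compound 4 (2.58 log units; beyond the scatter) is far larger than any seen before and separates two six-membered aromatic rings that both carry ring nitrogen, so ring nitrogen alone does not account for the low number of compound 3.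

This change alters two things at once, since 3-hydroxypyridin-2-yl has 1 hydrogen-bond donor and 1 ring hetero atom while pyridazin-3-yl has 0 hydrogen-bond donors and 2 ring hetero atoms, and the compounds shown cannot tell these apart. From the compounds shown here alone, a plain pyridin-2-yl, a 3-methoxypyridin-2-yl or a 3-aminopyridin-2-yl on the same carbonyl carbon would be the comparisons that bear on this, and how each would read remains open.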